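The source may hold more compounds than are shown below. What is called first, only, known or untested is meant among the compounds shown, and "the series" means these compounds.

Measured compounds:
Compound 1, `NC(=O)CC[C@H](NC(=O)CN(c1ncnc2c1ncn2C1CCCCO1)C1CC1)C(=O)OCc1ccccc1`, gives 39.4% in a functional assay on the whole organism (Tail, strain ICR) with Mus musculus as the target, in the tail flick test, with a stated time of 60 min, at a dose of 25 umol/kg by the oral route; on this read-out higher numbers stand for a stronger effect at the one dose given and lower numbers for a weaker effect.
Compound 2, `N=C(N)NCCC[C@H](NC(=O)CN(c1nc(Cl)nc2[nH]cnc12)C1CC1)C(=O)O`, gives 51% in this assay.

Of these two numbers, compound 1 holds the lower one: compound 2 lies higher by a margin that goes beyond the usual scatter, so the two compounds are distinct on this read-out.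

The step considered here leads from compound 1 to compound 3, `O=C(CN(c1ncnc2c1ncn2C1CCCCO1)C1CC1)N[C@@H](CC(=O)OCc1ccccc1)C(=O)OCc1ccccc1`, which has not yet been measured in this assay. The structural change is counted as benzyloxycarbonyl in place of carbamoylmethyl on a saturated chain carbon, two bonds along the chain from an amide-type nitrogen and a carbonyl carbon. Within the data shown here, compound 1 and compound 2 differ in several places at once, so nothing from that pair tells how this particular change should act; no single-change step between measured compounds is known, and only the two values themselves are available.

With that limited basis, the estimate for compound 3 is 35%, with a range from 10% to 65%. The estimated step is a number 4.4 percentage points lower from compound 1 to compound 3 (within the scatter), a change that is not expected to go beyond the scatter in either direction, though a wide range is allowed.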

Compound 3, a percentage reported as activity, at one dose (the size of the read-out at that dose, not a potency): 38.2%
Compound 3: the middle estimate sits 3.2 percentage points below what was measured; low and high end bracket the measured number.
By their numbers in this assay, from the lowest: compounds 3 and 1 (each within the scatter of the next); then compound 2.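

Among these compounds, at the saturated chain carbon, two bonds along the chain from an amide-type nitrogen and a carbonyl carbon, the swap of carbamoylmethyl for benzyloxycarbonyl gives the first single-change comparison in this assay: the step reads a number 1.2 percentage points lower from compound 1 to compound 3 (within the scatter), so the two compounds cannot be told apart on this read-out. The swap is not a small one: the entering group is larger, carries a six-membered aromatic ring of carbon only and lacks the hydrogen-bond donor of carbamoylmethyl. At this place, at this dose and time, the read-out accommodates both groups equally well. No measurement shown gives a reason for this result.

As far as these compounds go, it remains open whether any group at this place would separate from these two, for example a free carboxylic acid, a primary amine or a plain methyl group on the same chain carbon, or a longer chain carrying the same benzyl ester. A single dose at a single time also leaves open whether compound 1 and compound 3 would still match at other doses or at other times after dosing.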